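Following the Phenyl-to-Bromohydroxyphenyl Step from Compound 2

This account rests on a few compounds, and the source may have more. Where it says the series, first, only, none or still open, it means among the compounds named here.

Compound 1, `CCN(CC)c1ccc(/C=C/C(=O)c2ccc(OC)c3c2OC(C)(C)C=C3)cc1`, in a functional assay on HCT-116 cells (Homo sapiens) for antiproliferative activity, read by MTT assay, with a stated time of 24 h (on this read-out lower numbers stand for stronger inhibition and higher numbers for weaker inhibition), gives 620 nM.
Compound 2, `COc1ccc(C(=O)/C=C/c2ccccc2)c2c1C=CC(C)(C)O2`, gives in this assay only a limit, > 10000 nM.
Compound 3, `COc1ccc(C(=O)/C=C/c2cccc(C(F)(F)F)c2)c2c1C=CC(C)(C)O2`, gives in this assay 9710 nM.

Compound 2 thus stands at the weak end of the three, at the limit of > 10000 nM in this assay, at which 1 of the 3 values shown sits, with no number beyond that limit. Compound 4, `COc1ccc(C(=O)/C=C/c2ccc(O)c(Br)c2)c2c1C=CC(C)(C)O2`, differs from it by 3-bromo-4-hydroxyphenyl in place of phenyl on a double-bonded chain carbon bound to a double-bonded chain carbon. For the measured compounds named here, two measured steps touch this change, both altering the same ring. The step of an at least 16-fold higher number from compound 1 to compound 2 (1.20 log units; beyond the scatter) shows that a group on that ring can move the read-out a long way. The step of an at least 1.0-fold lower number from compound 2 to compound 3 (0.01 log units; that floor lies within the scatter) shows the opposite substituent leaving the number at the limit. The bromine and hydroxyl entering in compound 4 match neither precedent, so the direction is uncertain; a modest move below the limit seems the likelier outcome, with a real chance that only a limit is reported again. Compound 4 is therefore estimated at 4000 nM, between 1000 nM and 15000 nM. The expected step is an at least 2.5-fold lower number from compound 2 to compound 4 (0.39 log units; beyond the scatter).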

Compound 4, half-maximal inhibitory concentration: > 10000 nM
Compound 4 ended at the assay's limit; the forecaster's own chance of this, stated with the estimate: 35%; middle value at least 2.5-fold (0.39 log units) from the limit.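

For the compounds shown here, compound 2 and compound 4 both give only a limit in this assay, and no step between them can be read. The compounds shown leave open whether 3-bromo-4-hydroxyphenyl in place of phenyl changes the read-out at all, and in which direction.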